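Swapping a trifluoromethyl for a methoxy on the benzyl arm

A few compounds are considered here, and "the series" means these few. Any claim that something is new, unique, unknown or untested is made for them only; others in the source may bear on it.

Of the compounds shown here, three sharing one core have been tested in an ADME assay on isolated protein for inhibition of Amine oxidase [flavin-containing] B (Homo sapiens); a lower number here means a stronger inhibitor, a higher number a weaker inhibitor. Compound 1 `C#CCNC1CCc2c(SCCc3cccc(C)c3)cccc21` gives 4960 nM. Compound 2 `C#CCNC1CCc2c(SCc3ccc(C(F)(F)F)cc3)cccc21` gives 930 nM. Compound 3 `C#CCNC1CCc2c(SCc3ccc(Cl)c(Cl)c3)cccc21` gives 74 nM. Among these three, compound 2 stands in the middle: its number is below that of compound 1 and above that of compound 3, and both of those gaps are wider than the usual scatter of this assay.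

Compound 4 `C#CCNC1CCc2c(SCc3ccc(OC)cc3)cccc21` has not yet been measured in this assay. It differs from compound 2 in one spot: methoxy in place of trifluoromethyl on an aromatic carbon. The change sits on an aromatic carbon of a six-membered aromatic ring of carbon only, para to a large group. For the measured compounds named here, no measured pair in this set differs in this same way, so there is no direct precedent for the size of the step.

The shift from a trifluoromethyl to a methoxy is expected to weaken inhibition somewhat, giving a step from compound 2 to compound 4 of about a 2.2-fold higher number from compound 2 to compound 4 (0.33 log units; beyond the scatter) in this assay. On that basis, compound 4 is estimated to give 2000 nM in this assay, with a plausible range from 500 nM to 8000 nM.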

Compound 4, half-maximal inhibitory concentration: 3960 nM
The estimate for compound 4 lay 2.0-fold (0.30 log units) below the measured number; measured number inside the range.
By their numbers in this assay, from the lowest: compound 3; then compound 2; then compounds 4 and 1 (each within the scatter of the next).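

Read in this assay, replacing trifluoromethyl with methoxy on an aromatic carbon of the benzyl arm, para to a large group, gives a 4.3-fold higher number from compound 2 to compound 4 (0.63 log units; beyond the scatter). For the compounds shown here, this is the first pair in the set that differs in one place only, so this step can be tied to a single change rather than to several differences at once. It shows that inhibition responds to the group at this position, with the trifluoromethyl of compound 2 giving the stronger inhibitor of the two, although nothing available here explains why the step has this size.

One pair gives only two points at this position, so it cannot show whether other groups would follow any trend, or where a plain hydrogen, a hydroxyl or an amine on the same carbon would fall relative to compound 2 and compound 4. It also leaves open whether the same swap would give a step of similar size in a compound with a longer chain linking the ring to the sulfur.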